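A few compounds are considered here, and "the series" means these few. Any claim that something is new, unique, unknown or untested is made for them only; others in the source may bear on it.

Compounds measured in an ADME assay on HEL cells (Homo sapiens) for cytotoxicity, with a stated time of 3 days; on this read-out higher numbers stand for lower toxicity in this test and lower numbers for higher toxicity in this test:
compound 1, `CCC1(Cc2ccccc2)OS(=O)(=O)C=C1OCCCCc1ccccc1`, 99000 nM
compound 2, `CCC1(Cc2ccccc2)OS(=O)(=O)C=C1OCC(=O)OC`, a limit of the assay, > 200000 nM
compound 3, `CCC1(Cc2ccccc2)OS(=O)(=O)C=C1OCc1ccc(Cl)c(Cl)c1`, 36700 nM

Compound 3 holds the lowest of the two numbers shown in this assay. Its nearest neighbour is compound 1, and the step of a 2.7-fold lower number from compound 1 to compound 3 (0.43 log units; beyond the scatter) lies beyond the scatter. For compound 2 only a limit is reported, (the limit of > 200000 nM in this assay, at which 1 of the 3 values shown sits). The step of an at least 5.4-fold lower number from compound 2 to compound 3 (0.73 log units; beyond the scatter) therefore carries that floor.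

Compound 4, `CCC1(Cc2ccccc2)OS(=O)(=O)C=C1OCc1cccc(Cl)c1`, differs from compound 3 by hydrogen in place of chloro on an aromatic carbon. Within the data shown here, no measured step removes a single substituent from an aromatic ring; the steps of a 2.7-fold lower number from compound 1 to compound 3 (0.43 log units; beyond the scatter) and an at least 5.4-fold lower number from compound 2 to compound 3 (0.73 log units; beyond the scatter) each exchanged the whole group on the saturated chain carbon bound to an oxygen on an unsaturated carbon, and were modest at most. Removing one chloro is a smaller change than either, so a step within the scatter, if anything toward a higher number, is expected: a 1.5-fold higher number from compound 3 to compound 4 (0.18 log units; within the scatter). Compound 4 is therefore estimated at 55000 nM, with a range from 25000 nM to 120000 nM.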

Compound 4, half-maximal cytotoxic concentration: 50000 nM
Estimate against measurement, compound 4: 1.1-fold (0.04 log units) above, and the stated range covers the measured number.
By their numbers in this assay, from the lowest: compounds 3, 4 and 1 (each within the scatter of the next, the first and the last beyond it). At a limit, above all of these: compound 2.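

In this assay, among these compounds, this is the first step on the aromatic ring itself, and taking away the chloro that sits para to a large group stays within the scatter: a 1.4-fold higher number from compound 3 to compound 4 (0.13 log units; within the scatter). Against the 3-phenylpropyl compound, the single-chloro ring gives a 2.0-fold lower number from compound 1 to compound 4 (0.30 log units; within the scatter), which is within the scatter, unlike a 2.7-fold lower number from compound 1 to compound 3 (0.43 log units; beyond the scatter), yet compound 3 and compound 4 themselves cannot be told apart here. The separation from the methoxycarbonyl compound survives with one chloro, as an at least 4.0-fold lower number from compound 2 to compound 4 (0.60 log units; beyond the scatter), and this step is only a floor, set by a limit of the assay: the limit of > 200000 nM in this assay, at which 1 of the 4 values shown sits.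

Open, as far as these compounds go, is whether a phenyl ring carrying no chloro, or an amine in place of the remaining chloro, would shift the number beyond the scatter. Also open, from the compounds shown here alone, is what a carboxylic acid would give in place of methoxycarbonyl.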